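A few compounds are considered here, and "the series" means these few. Any claim that something is new, unique, unknown or untested is made for them only; others in the source may bear on it.

Compound 3 `CCCCCNc1cccc(NC(=O)c2ccc(OCCC)cc2)n1` stands in an in vitro assay on HEK-tsA201 cells for antagonist activity at Neuronal acetylcholine receptor; alpha4/beta2 (Homo sapiens), read by fluorescence and calcium flux (on this read-out lower numbers stand for stronger inhibition and higher numbers for weaker inhibition), at a limit of the assay, > 100000 nM, and gives no number. Compound 1 `CCCOc1ccc(C(=O)Nc2cccc(Br)n2)cc1` gives 80700 nM in this assay. Compound 2 `CCCOc1ccc(C(=O)Nc2cccc(Cl)n2)cc1` likewise sits at a limit, > 100000 nM. The steps of an at least 1.2-fold higher number from compound 1 to compound 2 (0.09 log units; that floor lies within the scatter) and an at least 1.2-fold higher number from compound 1 to compound 3 (0.09 log units; that floor lies within the scatter) both run toward weaker inhibition, while a step that the two limits leave unreadable from compound 2 to compound 3; the limit of > 100000 nM in this assay, at which 2 of the 3 values shown sit, marks where two of the three values rest. Compound 4 `CCCCCCNc1cccc(NC(=O)c2ccc(OCCC)cc2)n1` differs from compound 3 by methyl in place of hydrogen on a saturated chain carbon, five bonds along the chain from a nitrogen on an aromatic ring. Among the compounds with values here, none of the measured steps lengthens this chain, so nothing among them points to a readable step in this assay. Compound 4 is therefore expected to remain at the limit, estimated at 100000 nM with a range from 50000 nM to 300000 nM, which means a number no higher from compound 3 to compound 4 (the limit leaves the size open) is expected.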

Compound 4, half-maximal inhibitory concentration: > 100000 nM
Compound 4 was reported as a limit; the forecaster's own chance of this, stated with the estimate: 85%; the middle value sits exactly at the limit.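

Compound 4 shows that hexylamino, like pentylamino, gives no number at this position in this assay, so the added methyl on the chain reveals no gain in inhibition. Within the data shown here, the steps to compound 4 from compound 2 and from compound 3 cannot be read, and the one readable step, an at least 1.2-fold higher number from compound 1 to compound 4 (0.09 log units; that floor lies within the scatter), comes with hexylamino in place of bromo. Most values now rest at a single limit: the limit of > 100000 nM in this assay, at which 3 of the 4 values shown sit.

The compounds shown leave open whether a shorter chain such as ethylamino, or a cyclic amine such as piperidine, would give a number at this position.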